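The compounds below may be only part of what the source reports. "The series", "measured", "known", "first", "only" and "open" are said of these compounds alone.

Compound 1 `NS(=O)(=O)c1ccc(Nc2nncc3ccccc23)cc1` gives 23 nM in a functional assay on UO-31 cells (Homo sapiens) for antiproliferative activity, read by sulforhodamine B assay, with a stated time of 72 h; a higher number here means a weaker inhibitor, a lower number a stronger inhibitor. It stands level with compound 3 `O=S(=O)(Nc1ncccn1)c1ccc(Nc2nncc3ccccc23)cc1`, which gives 23 nM, and within the usual scatter of compound 2 `O=S(=O)(Nc1nccs1)c1ccc(Nc2nncc3ccccc23)cc1`, which gives 12 nM. The measured steps all alter the substituent on the sulfonamide nitrogen: a 1.9-fold lower number from compound 1 to compound 2 (0.28 log units; within the scatter), no change at the digits printed from compound 1 to compound 3 (within the scatter) and a 1.9-fold higher number from compound 2 to compound 3 (0.28 log units; within the scatter), each within the scatter. Compound 4 `Fc1ccc(Nc2nncc3ccccc23)cc1` differs from compound 1 thus: fluoro in place of sulfamoyl on an aromatic carbon. Among the compounds with values here, no measured step removes the sulfamoyl group itself, so none bears directly on this change; they show only that varying its nitrogen substituent leaves this assay unchanged beyond the scatter. With the whole group gone, a modest rise in the number is expected, with wide uncertainty. Compound 4 is estimated at 60 nM, range 15 nM to 300 nM, an expected step of a 2.6-fold higher number from compound 1 to compound 4 (0.42 log units; beyond the scatter).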

Compound 4, half-maximal inhibitory concentration: 4.7 nM
The estimate for compound 4 lay 13-fold (1.11 log units) above the measured number; measured number outside the range, below it.
By their numbers in this assay, from the lowest: compound 4; then compounds 2, 1 and 3 (each within the scatter of the next).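

In this assay, the sulfamoyl group on this aromatic carbon, para to a large group, proves dispensable: fluoro in its place gives a 4.9-fold lower number from compound 1 to compound 4 (0.69 log units; beyond the scatter) and so retains activity with no hydrogen-bond donor or acceptor there. The earlier compounds shown here varied only the substituent on the sulfonamide nitrogen, whereas this step replaces the entire group. Nothing available here accounts for the step.

As far as these compounds go, whether the lower number comes from fluoro itself or from the loss of sulfamoyl remains open. A plain hydrogen, chloro, an amine or a carboxylic acid at this position would help separate the two.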